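A few compounds are considered here, and "the series" means these few. Any claim that something is new, unique, unknown or untested is made for them only; others in the source may bear on it.

Three compounds share one core and differ only in the group carried on a nitrogen on an aromatic ring. Compound 1 `CC(=O)N(C)c1ccc2[nH]c(-c3n[nH]c4ccccc34)cc2n1` bears a methylcarbonyl there, compound 2 `CN(C(=O)C(C)(C)C)c1ccc2[nH]c(-c3n[nH]c4ccccc34)cc2n1` a (tert-butyl)carbonyl, and compound 3 `CN(C(=O)c1ccco1)c1ccc2[nH]c(-c3n[nH]c4ccccc34)cc2n1` a (furan-2-yl)carbonyl. In a functional assay on SMMC-7721 cells (Homo sapiens) for antiproliferative activity, read by MTT assay, with a stated time of 72 h (a lower number here means a stronger inhibitor, a higher number a weaker inhibitor), compound 1 gives 23400 nM, compound 2 gives 22200 nM, and compound 3 gives 28200 nM. Compound 2 has the lowest of the three numbers, but all three lie within the scatter of one another: the step of a 1.1-fold lower number from compound 1 to compound 2 (0.02 log units; within the scatter), the step of a 1.2-fold higher number from compound 1 to compound 3 (0.08 log units; within the scatter) and the step of a 1.3-fold higher number from compound 2 to compound 3 (0.10 log units; within the scatter) are each too small to count as a real change.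

Compound 4 `CN(c1ccc2[nH]c(-c3n[nH]c4ccccc34)cc2n1)S(=O)(=O)c1ccc(Cl)cc1` is not yet measured. It differs from compound 2 in one place: (4-chlorophenyl)sulfonyl in place of (tert-butyl)carbonyl on a nitrogen on an aromatic ring. Within the data shown here, the three measured steps all swap one carbonyl substituent for another and none of them moved the number beyond the scatter, so they bear on this step only loosely; none of them introduces a sulfonyl or a chlorine-bearing ring, so the new group has no precedent here. The expectation is therefore a step of a 1.1-fold lower number from compound 2 to compound 4 (0.05 log units; within the scatter) in this assay, with no clear direction, and compound 4 is estimated at 20000 nM, within a range from 7000 nM to 55000 nM.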

Compound 4, half-maximal inhibitory concentration: 12700 nM
For compound 4 the middle estimate is 1.6-fold (0.20 log units) above the measured one, within the range that was stated.
By their numbers in this assay, from the lowest: compounds 4, 2, 1 and 3 (each within the scatter of the next, the first and the last beyond it).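

The nitrogen on the aromatic ring accepts more than carbonyl groups: (4-chlorophenyl)sulfonyl, the larger group with its own six-membered aromatic ring, brings no loss of activity in this assay. Against the two aliphatic carbonyl groups the change is small, with a 1.7-fold lower number from compound 2 to compound 4 (0.24 log units; within the scatter) and a 1.8-fold lower number from compound 1 to compound 4 (0.27 log units; within the scatter), so compound 4 cannot be ranked ahead of either compound 2 or compound 1. Among these compounds, only a 2.2-fold lower number from compound 3 to compound 4 (0.35 log units; beyond the scatter) clears the scatter, and it is the first step in this set to do so, though a modest one, while nothing here gives a reason for the shift.

The swap changes the carbonyl to a sulfonyl and brings in the chlorine-bearing ring in a single step, so these compounds cannot show which of the two parts accounts for the difference from compound 3. A phenylsulfonyl group without the chlorine and a methylsulfonyl group would separate those parts, and an amine-bearing chain on the same nitrogen would test whether anything outside these neutral groups moves the number further.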